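The compounds below may be only part of what the source reports. "The series", "measured", "known", "first", "only" and "open" are said of these compounds alone.

Measured so far:
- compound 1, `CC(C)OC(=O)C1CN(C(=O)c2ccc(F)cc2)CC(C)(C)c2cc(C#N)[nH]c21`: 640 nM
- compound 2, `CC(C)OC(=O)C1=CN(C(=O)c2cccc(C(F)(F)F)c2)CC(C)(C)c2cc(C#N)[nH]c21`: 8.5 nM

Both values come from an assay on HEK293 cells for agonist activity at Bile acid receptor (Homo sapiens), read by a luciferase reporter; a higher number here means that more compound is needed for the effect, a lower number that less compound is needed. Compound 1 gives 640 nM, the higher of the two numbers in hand, and compound 2 gives 8.5 nM; the two structures differ in more than one place, so their gap is noted only as what the numbers show, with compound 1 standing on the weaker side.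

The next compound is compound 3, `CC(C)OC(=O)C1CN(C(=O)C2CCOCC2)CC(C)(C)c2cc(C#N)[nH]c21`, which is not yet measured in this assay. It is derived from compound 1 by a single change, (oxan-4-yl in place of 4-fluorophenyl on a carbonyl carbon), on the carbonyl carbon whose other neighbour is the amide-type nitrogen in a ring. Among the measured compounds shown here, no measured pair in this set isolates that change, so there is no step to lean on; the only anchor is compound 1 itself.

The expectation for compound 3 is therefore a modest shift toward a higher number, a 1.6-fold higher number from compound 1 to compound 3 (0.19 log units; within the scatter), with a wide range to cover the absence of a precedent. For compound 3 the estimated value in this assay is 1000 nM, expected to fall between 250 nM and 4000 nM.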

Compound 3, half-maximal effective concentration: 3300 nM
Estimate against measurement, compound 3: 3.3-fold (0.52 log units) below; the range from low to high includes it.
By their numbers in this assay, from the lowest: compound 2; then compound 1; then compound 3.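

In this assay the group on the carbonyl carbon whose other neighbour is the amide-type nitrogen in a ring proves to matter: oxan-4-yl in place of 4-fluorophenyl gives a 5.2-fold higher number from compound 1 to compound 3 (0.71 log units; beyond the scatter), a step beyond the usual scatter. For this one pair, the six-membered aromatic ring of carbon only goes with the lower number, and the non-aromatic ring with a hetero atom and a hydrogen-bond acceptor goes with the higher one, although a single step cannot separate the loss of the aromatic ring, the loss of fluorine and the arrival of the ring oxygen. No measurement here bears on the reason for this step.

Cyclohexyl would keep a non-aromatic ring of carbon only, and pyridin-4-yl would keep an aromatic ring with a ring nitrogen, so either could help show which part of the change counts, but where each would fall relative to compound 1 and compound 3 remains open. Also open, on these data alone, is whether the same change would give a step of similar size on the core of compound 2.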